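A few compounds are considered here, and "the series" means these few. Any claim that something is new, unique, unknown or untested is made for them only; others in the source may bear on it.

Working notes on a small set of fused-core compounds carrying a chloromethyl-substituted benzyl group. Compound 1 `Nc1nc(Cl)c2ncn(Cc3ccc(CCl)cc3)c2n1`, compound 2 `ClCc1cccc(Cn2cnc3nc(Cl)nc(Cl)c32)c1` and compound 3 `ClCc1ccccc1Cn1cnc2ncnc(Cl)c21` have been run in a functional assay on U-251 cells (Homo sapiens) for cytotoxicity, read by sulforhodamine B assay, with a stated time of 48 h; on this read-out lower numbers stand for stronger inhibition of growth and higher numbers for weaker inhibition of growth. Compound 1 gives 3550 nM, compound 2 gives 1380 nM and compound 3 gives 1900 nM. Among these three numbers compound 2 has the lowest, but compound 3 lies within the usual scatter of it, so no order between the two can be read; only compound 1 stands apart, beyond the scatter, with the weakest growth inhibition of the set.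

Compound 4 `ClCc1cccc(Cn2cnc3ncnc(Cl)c32)c1` has not yet been measured. It differs from compound 2 in one place: hydrogen in place of chloro on an aromatic carbon. Compound 3 carries hydrogen rather than chloro at the corresponding position of its core, and its value 1900 nM sits close to compound 2, so a large effect of this exchange is not anticipated, though compound 3 also differs in how its benzyl group is substituted. The expected step in this assay from compound 2 to compound 4 is therefore small, a 1.4-fold higher number from compound 2 to compound 4 (0.16 log units; within the scatter), in the direction of slightly weaker growth inhibition, within or just at the scatter. For compound 4 the estimated value is 2000 nM, with a range from 900 nM to 4500 nM.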

Compound 4, concentration for 50% growth inhibition: 1940 nM
For compound 4 the middle estimate is 1.0-fold (0.01 log units) above the measured one; measured number inside the range.
By their numbers in this assay, from the lowest: compounds 2, 3, 4 and 1 (each within the scatter of the next, the first and the last beyond it).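

For the compounds shown here, the pair of compound 2 and compound 4 gives the first reading in this assay of a change at a single place, the aromatic carbon between two ring nitrogen atoms: hydrogen in place of chloro gives a 1.4-fold higher number from compound 2 to compound 4 (0.15 log units; within the scatter) and so leaves no difference that can be read. The earlier compounds shown here differed from one another in more than one place and could not isolate this position, whereas this pair shows that, with the rest of compound 2 held constant, growth inhibition in this range does not depend on a chloro group there. No measurement at hand offers an explanation for this result.

Going by these compounds alone, whether a larger or different group at this position, such as methoxy, methyl or a nitrile, would produce a step beyond the scatter remains open, since chloro and hydrogen are the only two groups compared there in a matched pair. Also open, going by these compounds, is whether the same exchange would read alike with the chloromethyl group elsewhere on the benzyl ring or with the other chloro group of the core replaced.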